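This account rests on a few compounds, and the source may have more. Where it says the series, first, only, none or still open, it means among the compounds named here.

Of the compounds shown here, two of a shared core have been measured in an assay on isolated protein for binding affinity to Oxytocin receptor (Homo sapiens); on this read-out higher numbers stand for weaker inhibition and lower numbers for stronger inhibition. Compound 1 `CC(C)C[C@@H]1C(=O)N[C@H](C2Cc3ccccc3C2)C(=O)N1[C@@H](C(=O)NC(C)(C)C)c1ccoc1` gives 12.6 nM. Compound 2 `CC(C)C[C@@H]1C(=O)N[C@H](C2Cc3ccccc3C2)C(=O)N1[C@@H](C(=O)NC(C)C)c1ccc(Br)o1` gives 0.794 nM, the lower of the two numbers; the gap to compound 1 lies beyond the usual scatter of such measurements, so compound 2 stands as the stronger binder of the pair. Compound 3 `CC(C)C[C@@H]1C(=O)N[C@H](C2Cc3ccccc3C2)C(=O)N1[C@@H](C(=O)NC(C)C)c1cc(Br)cs1` is not yet measured in this assay. It differs from compound 2 in a single place: 4-bromothiophen-2-yl in place of 5-bromofuran-2-yl on a saturated chain carbon bound to an amide-type nitrogen in a ring and a carbonyl carbon. Going by the values given here, no measured pair shows this exchange of one five-membered aromatic ring for another, so the size of the step has no direct precedent. Because compound 2 already gives 0.794 nM, the expectation is that compound 3 keeps a number of the same order, with a step from compound 2 to compound 3 that is estimated as a 1.4-fold higher number from compound 2 to compound 3 (0.14 log units; within the scatter), not clearly beyond the scatter. In this assay compound 3 is thus estimated at 1.1 nM, expected to fall between 0.3 nM and 4 nM.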

Compound 3, inhibition constant: 1 nM
The estimate for compound 3 lay 1.1-fold (0.04 log units) above the measured number; the measured number falls inside the stated range.
By their numbers in this assay, from the lowest: compounds 2 and 3 (each within the scatter of the next); then compound 1.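

Read in this assay, the exchange of 5-bromofuran-2-yl for 4-bromothiophen-2-yl gives a 1.3-fold higher number from compound 2 to compound 3 (0.10 log units; within the scatter), so the two groups cannot be told apart on this read-out. Going by these compounds alone, this is the first direct comparison at this place, on a saturated chain carbon bound to an amide-type nitrogen in a ring and a carbonyl carbon, and it shows that a bromine-bearing ring with sulfur and one with oxygen read alike here. No supporting data bear on why they do.

As far as these compounds go, whether the bromine itself counts stays open: compound 1 differs from compound 2 in more than one place, so that gap cannot be assigned to the bromine, the ring or the amide group alone. Nor do the compounds shown tell how a pyridine ring, or a chlorine or methyl group in place of the bromine, would read at this position.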